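A few compounds are considered here, and "the series" means these few. Any claim that something is new, unique, unknown or untested is made for them only; others in the source may bear on it.

Measured so far in a toxicity assay on NIH3T3 cells (Mus musculus) for cytotoxicity, read by resazurin assay; on this read-out higher numbers stand for an effect only at larger amounts of compound and lower numbers for an effect already at smaller amounts:
Compound 1 `COC(=O)c1ccc(NCc2cncn2Cc2cccc(Br)c2)cc1-c1ccccc1`: > 10000 nM (a limit)
Compound 2 `COC(=O)c1ccc(NCc2cncn2Cc2ccccc2)cc1-c1ccccc1`: > 1000 nM (a limit)

Neither compound has yielded an actual number. Compound 2 stands at the limit of > 1000 nM in this assay, at which 1 of the 2 values shown sits, so its position is known only as a limit and not as a number. Compound 1 stands at the limit of > 10000 nM in this assay, at which 1 of the 2 values shown sits, which is also only a limit.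

Compound 3 `COC(=O)c1ccc(NCc2cncn2Cc2ccc(N)cc2)cc1-c1ccccc1` has not yet been measured. It is reached from compound 2 by amino in place of hydrogen on an aromatic carbon, turning benzyl to 4-aminobenzyl, with amino in place of hydrogen on an aromatic carbon.

Among the measured compounds shown here, the only measured step that bears on this change is a step that the two limits leave unreadable from compound 1 to compound 2, a replacement of bromo by hydrogen on the benzyl group. For the measured compounds named here, it offers no size to carry over, and no measured compound carries the amino group. The expectation in this assay therefore rests on the limit of compound 2 at > 1000 nM and on the limit of compound 1 at > 10000 nM, and it leans toward higher numbers. The expected step is a step that the limit leaves unreadable from compound 2 to compound 3, a loosely held estimate.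

For compound 3 the estimated value is 8000 nM, with an expected range from 2000 nM to 30000 nM.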

Compound 3, half-maximal effective concentration: > 10000 nM
Compound 3 ended at the assay's limit; the forecaster's own chance of this, stated with the estimate: 60%; middle value at least 1.2-fold (0.09 log units) from the limit.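

Compound 3 gives only a limit in this assay, > 10000 nM. Among the compounds shown here, compound 1 and compound 2 also stand at limits, so no step among the three compounds can be read. The compounds shown leave open where any of them would give an actual number, and whether the amino or bromo group changes it.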